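The source may report more compounds than this note shows. Statements on the series, on what has been measured and on what is new or still open speak of the compounds shown alone.

Of the compounds shown here, three built on one shared core have been tested in an assay for inhibition of Tryptophan 2,3-dioxygenase (Homo sapiens), with a stated time of 1 h, tested at 10 uM; on this read-out higher numbers stand for more inhibition at the one concentration tested (going by the name of the read-out) and lower numbers for less inhibition. Compound 1 `Oc1cccc(CNc2cc(Br)cc3[nH]ncc23)c1` gives 55% in this assay, and compound 2 `N#Cc1ccc(CNc2cc(Br)cc3[nH]ncc23)cc1` gives 73%. Compound 3 `Oc1ccc(CNc2cc(Br)cc3[nH]ncc23)cc1O` is reported in this assay as "not active" (no number reported), so no number stands for it and it cannot be placed among the others. Compound 4 `Oc1ccc(CNc2cc(Br)cc3[nH]ncc23)cc1Cl` is yet to be measured; it differs from compound 3 by chloro in place of hydroxy on an aromatic carbon. Going by the values given here, no measured pair shows this change, so the size of the step in this assay cannot be read from a comparison. For compound 4 a number in this assay somewhat below that of compound 1 is expected, since compound 1 gives 55% there. Compound 4 is therefore estimated at 45%, between 10% and 80%.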

Compound 4, a percentage reported as inhibition, at one concentration (the size of the read-out at that concentration, not a potency): 19%
Compound 4: middle estimate off by 26 percentage points, on the high side; measured number inside the range.
By their numbers in this assay, from the lowest: compound 4; then compound 1; then compound 2.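

Going by these compounds alone, compound 3 has no number, and no step from it to compound 4 can be read. The compounds shown leave open how far chloro in place of hydroxy shifts inhibition. Nothing available here explains the value of compound 4.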